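Swapping a Fluorinated Tail for a Branched Alkyl Chain

This account rests on a few compounds, and the source may have more. Where it says the series, first, only, none or still open, it means among the compounds named here.

Compound 1 `CCCCCCOc1ccc(C(CC(=O)O)c2ccccc2)cc1`: 2.88 uM
Compound 2 `O=C(O)CC(c1ccccc1)c1ccc(OCCCC(F)(F)F)cc1`: 3.16 uM

Within the data shown here, in a functional assay on HEK293 cells for agonist activity at Free fatty acid receptor 1 (Homo sapiens), read by calcium flux (a higher number here means that more compound is needed for the effect, a lower number that less compound is needed), compound 2 gives 3.16 uM, the highest of the two numbers so far, while compound 1 gives 2.88 uM, which lies within the scatter of that. Compound 3 `CCC(C)COc1ccc(C(CC(=O)O)c2ccccc2)cc1` has not been measured yet; it differs from compound 2 by sec-butyl in place of 3,3,3-trifluoropropyl on a saturated chain carbon bound to an oxygen on an aromatic ring. Among the measured compounds shown here, the single measured step, a 1.1-fold higher number from compound 1 to compound 2 (0.04 log units; within the scatter), also reshaped the chain attached to the aromatic oxygen and stayed within the scatter. Compound 3 is therefore expected to give 3 uM, with a range from 1.5 uM to 6 uM, which means an expected 1.1-fold lower number from compound 2 to compound 3 (0.02 log units; within the scatter).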

Compound 3, concentration for half-maximal effect: 0.3 uM
Compound 3: middle estimate off by 10-fold (1.00 log units), on the high side; measured number below the stated range.
By their numbers in this assay, from the lowest: compound 3; then compounds 1 and 2 (each within the scatter of the next).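

Unlike the earlier swap, this change shows that the chain on the aromatic oxygen can matter a great deal in this assay: sec-butyl in place of 3,3,3-trifluoropropyl gives an 11-fold lower number from compound 2 to compound 3 (1.02 log units; beyond the scatter) and sec-butyl in place of pentyl gives a 9.6-fold lower number from compound 1 to compound 3 (0.98 log units; beyond the scatter) in this series. Of these three compounds, only compound 3 carries a branched chain, and it alone stands apart. Nothing measured here gives a reason for the difference.

As far as these compounds go, whether the branch itself matters, or its exact place on the chain, stays open. A straight butyl chain or a 3-methylbutyl chain at this position would help separate these possibilities.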